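The source may report more compounds than this note shows. Statements on the series, on what has been measured and on what is new or still open speak of the compounds shown alone.

Of the compounds shown here, three on the shared core have been read in a functional assay on DU-145 cells (Homo sapiens) for cytotoxicity, read by MTT assay; a higher number here means a weaker inhibitor, a lower number a stronger inhibitor: compound 1 (`CC(C)=CC[C@@H](OC(=O)CC(O)c1ccccc1)C1=CC(=O)c2c(O)ccc(O)c2C1=O`) gives 17000 nM, compound 2 (`CCCC(C)(O)CC(=O)O[C@H](CC=C(C)C)C1=CC(=O)c2c(O)ccc(O)c2C1=O`) gives 75000 nM, and compound 3 (`CC(C)=CC[C@@H](OC(=O)C1CCCCO1)C1=CC(=O)c2c(O)ccc(O)c2C1=O`) gives 24700 nM. The measured step of a 1.5-fold higher number from compound 1 to compound 3 (0.16 log units; within the scatter) lies within the scatter, so those two values cannot be told apart. The other comparison is clearer: a 3.0-fold lower number from compound 2 to compound 3 (0.48 log units; beyond the scatter).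

Compound 4 (`CCCCC(C)(O)CC(=O)O[C@H](CC=C(C)C)C1=CC(=O)c2c(O)ccc(O)c2C1=O`) carries 2-hydroxy-2-methylhexyl in place of oxan-2-yl on a carbonyl carbon. The closest guide is compound 2, whose 2-hydroxy-2-methylpentyl differs from the entering group by its chain name alone, and the step of a 3.0-fold lower number from compound 2 to compound 3 (0.48 log units; beyond the scatter) is the one that bears most directly. The step of a 4.4-fold higher number from compound 1 to compound 2 (0.64 log units; beyond the scatter) offers weaker support, since it involves a different group. Both rest on a single compound, so no pattern is claimed. A modest move toward a higher number is therefore expected in this assay.

The expected change is a 2.2-fold higher number from compound 3 to compound 4 (0.35 log units; beyond the scatter). For compound 4, the estimate is 55000 nM, with an expected range of 22000 nM to 120000 nM.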

Compound 4, half-maximal inhibitory concentration: 76500 nM
For compound 4 the middle estimate is 1.4-fold (0.14 log units) below the measured one; the measured number falls inside the stated range.
By their numbers in this assay, from the lowest: compounds 1 and 3 (each within the scatter of the next); then compounds 2 and 4 (each within the scatter of the next).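

Lengthening the chain from 2-hydroxy-2-methylpentyl to 2-hydroxy-2-methylhexyl gives no readable shift in this assay, with a 1.0-fold higher number from compound 2 to compound 4 (0.01 log units; within the scatter), so compound 2 and compound 4 cannot be told apart. A second open-chain group on the carbonyl carbon now separates from oxan-2-yl, with a 3.1-fold higher number from compound 3 to compound 4 (0.49 log units; beyond the scatter), and from the phenyl-bearing chain of compound 1, with a 4.5-fold higher number from compound 1 to compound 4 (0.65 log units; beyond the scatter), so among these four compounds both branched hydroxy-alkyl chains sit on the higher-number side, and no compound shown goes against this. No measurement at hand accounts for these steps.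

Still open, as far as these compounds go, is whether a longer chain, such as 2-hydroxy-2-methyloctyl, would keep the number in this assay where it stands. Equally open, from the compounds shown here alone, is what an amine or a carboxylic acid in place of the chain's hydroxy would do.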